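A few compounds are considered here, and "the series" means these few. Any claim that something is new, unique, unknown or untested is made for them only; others in the source may bear on it.

Compound 1 `COC(=O)c1ccc(OCc2oc(-c3ccccc3OC)nc2C)cc1` is tested in an assay on cells for antagonist activity at vitamin D3 receptor (Homo sapiens), read by a luciferase reporter (a lower number here means a stronger inhibitor, a higher number a weaker inhibitor), where compound 1 gives 17900 nM, the highest of the two numbers shown. Compound 2 `COC(=O)c1ccc(OCc2oc(-c3cccc(OC)c3)nc2C)cc1` gives 8890 nM, and the step of a 2.0-fold lower number from compound 1 to compound 2 (0.30 log units; within the scatter) stays within the scatter. Compound 3 `COc1ccccc1-c1nc(C)c(COc2ccccc2C(=O)O)o1` reaches only a limit of the assay, > 80000 nM, a limit at which (the limit of > 80000 nM in this assay, at which 1 of the 3 values shown sits). Compound 4 `COc1ccccc1-c1nc(C)c(COc2ccc(CC(=O)O)cc2)o1` differs from compound 1 by carboxymethyl in place of methoxycarbonyl on an aromatic carbon. Going by the values given here, no measured step shares this change; the step from compound 1 to compound 2 moves the methoxy group instead. Compound 3, which carries a free carboxylic acid in place of the ester, gives only a limit in this assay. Compound 4 is expected to give about 30000 nM, between 9000 nM and 80000 nM. That expected result would be a step of a 1.7-fold higher number from compound 1 to compound 4 (0.22 log units; within the scatter), a weakening.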

Compound 4, half-maximal inhibitory concentration: > 80000 nM
Compound 4: no number, only a limit; the forecaster's own chance of this, stated with the estimate: 30%; middle value at least 2.6-fold (0.42 log units) from the limit.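

Carboxymethyl in place of methoxycarbonyl, on an aromatic carbon para to a large group, brings a real loss in this assay: the change is an at least 4.4-fold higher number from compound 1 to compound 4 (0.65 log units; beyond the scatter). Compound 4 gives only a limit, so this step has a minimum size but no exact one. Compound 3 and compound 4, the two compounds shown with a free carboxylic acid, both stop at the same limit: the limit of > 80000 nM in this assay, at which 2 of the 4 values shown sit.

The compounds shown do not tell whether the free acid itself or the altered chain matters here. A methyl ester on the same chain, or an amide at this place, would separate the two.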